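The source may hold more compounds than are shown below. What is called first, only, known or untested is meant among the compounds shown, and "the series" means these compounds.

In a functional assay on A549 cells (Homo sapiens) for antiproliferative activity, read by MTT assay, with a stated time of 48 h (on this read-out lower numbers stand for stronger inhibition and higher numbers for weaker inhibition), compound 1 (`COc1ccc(/C=C/C(=O)Nc2cc3c(Nc4ccc(Cl)c(Cl)c4)ncnc3s2)cc1`) gives 3320 nM. Compound 2 (`O=C(/C=C/c1ccccc1)Nc1cc2c(Nc3ccc(F)c(Cl)c3)ncnc2s1`) gives 11200 nM, the higher of the two numbers and separated from compound 1 by more than the scatter. Compound 3 (`O=C(/C=C/c1ccccc1)Nc1cc2c(Nc3ccc(Cl)c(Cl)c3)ncnc2s1`) is compound 2 with chloro in place of fluoro on an aromatic carbon, ortho to a chloro group and para to a large group, so that 3-chloro-4-fluorophenyl becomes 3,4-dichlorophenyl (chloro in place of fluoro on an aromatic carbon). Among the measured compounds shown here, no measured pair shows this change alone. Compound 1 has the 3,4-dichlorophenyl group and gives 3320 nM, yet it also differs from compound 2 elsewhere, so it offers only a weak hint. A small move toward stronger inhibition, close to the scatter, is therefore expected in this assay, with an estimated step of a 1.7-fold lower number from compound 2 to compound 3 (0.24 log units; within the scatter). For compound 3 the estimated value is 6500 nM, with a likely range of 2500 nM to 15000 nM.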

Compound 3, half-maximal inhibitory concentration: 7600 nM
Compound 3: middle estimate off by 1.2-fold (0.07 log units), on the low side; low and high end bracket the measured number.
By their numbers in this assay, from the lowest: compound 1; then compounds 3 and 2 (each within the scatter of the next).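

In this assay, replacing fluoro with chloro at this position gives a 1.5-fold lower number from compound 2 to compound 3 (0.17 log units; within the scatter), so compound 2 and compound 3 cannot be told apart, and this swap leaves no clear mark on the read-out. The gap between compound 1 and compound 2 mixed two changes, and compound 3 now separates them. Hydrogen in place of methoxy on an aromatic carbon gives a 2.3-fold higher number from compound 1 to compound 3 (0.36 log units; beyond the scatter), a modest step but a real one, so the methoxy side is where this small set shows a readable difference. No measurement here explains why the numbers fall this way.

Open, going by these compounds, is whether bromo at the halogen position, or ethoxy or hydroxy in place of methoxy, would read differently. Also open, on these data alone, is whether the methoxy step holds on the 3-chloro-4-fluorophenyl compounds.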